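The compounds below may be only part of what the source reports. "The series", "measured", "known", "first", "only" and "open" are said of these compounds alone.

In a functional assay on HCT-116 cells (Homo sapiens) for antiproliferative activity, read by MTT assay, with a stated time of 48 h (on this read-out higher numbers stand for weaker inhibition and lower numbers for stronger inhibition), compound 1 `Cc1ccccc1-n1nncc1CN1C(=O)C2(C(C#N)=C(N)Oc3c2c2nc4ccccc4nc2c2ccccc32)c2ccccc21` returns only a limit of the assay, > 50000 nM. Among the measured compounds shown here, compound 2 `CCc1ccccc1-n1nncc1CN1C(=O)C2(C(C#N)=C(N)Oc3c(N)cc4nc5ccccc5nc4c32)c2ccccc21` gives 10300 nM in this assay, the single number in the set. The open question is compound 3 `CCOc1ccc(-n2nncc2CN2C(=O)C3(C(C#N)=C(N)Oc4c(N)cc5nc6ccccc6nc5c43)c3ccccc32)cc1`, where the change is 4-ethoxyphenyl in place of 2-ethylphenyl on an aromatic nitrogen. For the measured compounds named here, no measured pair shares this change, so there is nothing to set its size; the expected step is a 1.0-fold lower number from compound 2 to compound 3 (0.01 log units; within the scatter), none beyond the scatter. Compound 3 is accordingly estimated at 10000 nM in this assay, within 3000 nM to 40000 nM.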

Compound 3, half-maximal inhibitory concentration: > 50000 nM
Compound 3 gave a limit, no number; the forecaster's own chance of this, stated with the estimate: 15%; middle value at least 5.0-fold (0.69 log units) from the limit.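

The aryl group on the aromatic nitrogen is not a free position: 4-ethoxyphenyl in place of 2-ethylphenyl gives an at least 4.8-fold higher number from compound 2 to compound 3 (0.68 log units; beyond the scatter) in this assay. Compound 3 returns > 50000 nM, a limit of the assay. The true size of the step therefore stays unknown, because only a limit is available for compound 3: the limit of > 50000 nM in this assay, at which 2 of the 3 values shown sit.

This single step cannot separate the oxygen of the ethoxy group from the different place of the substituent on the phenyl ring. As far as these compounds go, whether a plain phenyl, an amine or a longer chain at this position keeps a measurable value remains open.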